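Chloro for methoxy on the shared core: compound 4

A few compounds are considered here, and "the series" means these few. Any claim that something is new, unique, unknown or untested is made for them only; others in the source may bear on it.

Compound 1, `COc1ccc2[nH]c(-c3nc(C)no3)cc2c1`: 19900 nM in a functional assay on Jurkat cells (Homo sapiens) for antiproliferative activity, read by WST assay, with a stated time of 72 h; a higher number here means a weaker inhibitor, a lower number a stronger inhibitor.
Compound 2, `Cc1noc(-c2cc3cc(Cl)ccc3[nH]2)n1`: 21600 nM in this assay.
Compound 3, `COc1ccc2[nH]c(-c3nc(-c4ccc(Cl)cc4)no3)cc2c1`: reported only as a limit, > 50000 nM in this assay.

Compound 3 carries the 4-chlorophenyl in place of the methyl of compound 1, and an at least 2.5-fold higher number from compound 1 to compound 3 (0.40 log units; beyond the scatter). For compound 3 itself only a limit is known, (the limit of > 50000 nM in this assay, at which 1 of the 3 values shown sits), so its true position is somewhere beyond that point.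

The change to compound 4, `Clc1ccc(-c2noc(-c3cc4cc(Cl)ccc4[nH]3)n2)cc1`, is chloro in place of methoxy on an aromatic carbon. The same exchange has been measured once in this set, between compound 1 and compound 2: a 1.1-fold higher number from compound 1 to compound 2 (0.04 log units; within the scatter). That step was within the scatter, so no movement beyond the scatter is expected in this assay on going from compound 3 to compound 4, in either direction, and the expected step is a step that the limit leaves unreadable from compound 3 to compound 4.

Compound 4 is therefore expected at about 60000 nM, with a range from 25000 nM to 150000 nM, and the most likely outcome is that it too is reported only as a limit.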

Compound 4, half-maximal inhibitory concentration: > 50000 nM
Compound 4 ended at the assay's limit; the forecaster's own chance of this, stated with the estimate: 75%; the middle value is on the limit's open side.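

On the core of compound 2, 4-chlorophenyl in place of methyl gives an at least 2.3-fold higher number from compound 2 to compound 4 (0.36 log units; beyond the scatter) in this assay, so the change seen on the core of compound 1 now holds on a second core: the same change on two cores in this assay, an at least 2.5-fold higher number (0.40 log units; beyond the scatter) from compound 1 to compound 3 and an at least 2.3-fold higher number (0.36 log units; beyond the scatter) from compound 2 to compound 4; the limit leaves it open whether they differ. The step from compound 3 to compound 4, chloro in place of methoxy, cannot be read, with both compounds at a limit: the limit of > 50000 nM in this assay, at which 2 of the 4 values shown sit. That exchange therefore has a readable size only where methyl is present, as a 1.1-fold higher number from compound 1 to compound 2 (0.04 log units; within the scatter).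

From the compounds shown here alone, how far compound 3 and compound 4 lie beyond the limit stays open, and with it whether the 4-chlorophenyl step differs between the two cores and whether chloro and methoxy differ at all when 4-chlorophenyl is present. Also open, going by these compounds, is what other groups do in place of methyl: a plain phenyl, an ethyl chain or a dimethylamino group would show whether the higher numbers are tied to 4-chlorophenyl or follow from other replacements of methyl as well.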